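The source may report more compounds than this note shows. Statements on the series, on what has been measured and on what is new or still open speak of the compounds shown alone.

Values in a functional assay on Raji cells (Homo sapiens) for cytotoxicity, read by MTT assay, with a stated time of 48 h (a lower number here means a stronger inhibitor, a higher number a weaker inhibitor), for the measured members of the series:

compound 1 `O=C(O)CN1C(=O)/C(=C/c2nc3ccccc3n2Cc2ccc(Br)cc2)SC1=S`: 1190 nM
compound 2 `O=C(O)CN1C(=O)/C(=C/c2nc3ccccc3n2Cc2ccc(Br)cc2F)SC1=S`: 11400 nM
compound 3 `O=C(O)CN1C(=O)/C(=C/c2nc3ccccc3n2Cc2ccccc2F)SC1=S`: 1230 nM

The two cores of compound 1 and compound 3 differ by 2-fluorophenyl in place of 4-bromophenyl on a saturated chain carbon bound to an aromatic nitrogen; in this assay the step from one to the other is a 1.0-fold higher number from compound 1 to compound 3 (0.01 log units; within the scatter), so the two cores can be treated as equivalent starting points here.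

On compound 1, the change (fluoro in place of hydrogen on an aromatic carbon), set ortho to a large group; meta to a bromo group, yields compound 2 and gives a 9.6-fold higher number from compound 1 to compound 2 (0.98 log units; beyond the scatter) in this assay.

Compound 4 `O=C(O)CN1C(=O)/C(=C/c2nc3ccccc3n2Cc2ccc(F)cc2F)SC1=S`, not yet measured, carries the same kind of change on compound 3, namely (fluoro in place of hydrogen on an aromatic carbon), but here set meta to a fluoro group; para to a large group, so the surroundings of the new fluoro differ from those in compound 2.

For compound 4 a move toward a higher number is expected, estimated as a 3.0-fold higher number from compound 3 to compound 4 (0.48 log units; beyond the scatter) in this assay; this rests on compound 1 and compound 2 having shown a 9.6-fold higher number from compound 1 to compound 2 (0.98 log units; beyond the scatter), though the place of the change is not the same, which tempers the estimate.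

Compound 4 is therefore estimated at 3700 nM in this assay, expected to lie between 1200 nM and 12000 nM.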

Compound 4, half-maximal inhibitory concentration: 8960 nM
The estimate for compound 4 lay 2.4-fold (0.38 log units) below the measured number; the measured number falls inside the stated range.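

In this assay the new step, a 7.3-fold higher number from compound 3 to compound 4 (0.86 log units; beyond the scatter), repeats what the same fluoro for hydrogen change did on the core of compound 1, and the two rises in the number match: the same change on two cores in this assay, a 9.6-fold higher number (0.98 log units; beyond the scatter) from compound 1 to compound 2 and a 7.3-fold higher number (0.86 log units; beyond the scatter) from compound 3 to compound 4, 1.3-fold (0.12 log units) apart, within the scatter of two such steps

The step of a 1.3-fold lower number from compound 2 to compound 4 (0.10 log units; within the scatter) leaves fluoro and bromo para to a large group indistinguishable once the 2-fluorobenzyl pattern is present, while a 7.5-fold higher number from compound 1 to compound 4 (0.88 log units; beyond the scatter) places the 2,4-difluorobenzyl compound on the weaker side of the bromobenzyl parent. These two pairs show that the change carries across these two cores only, with the new fluoro in different surroundings on each, and they do not show why the number rises or whether the rise holds on any other core.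

Open, going by these compounds, is whether a chloro or a methoxy group para to a large group would give the same rise as fluoro and bromo do. Also open, on these data alone, is whether the rise survives on an unsubstituted benzyl group, or when the carboxylic acid gives way to an amide.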